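A difluoromethoxy swap at the limit of growth inhibition

A few compounds are considered here, and "the series" means these few. Any claim that something is new, unique, unknown or untested is made for them only; others in the source may bear on it.

In a functional assay on K562 cells (Homo sapiens) for antiproliferative activity, read by MTT assay, with a stated time of 48 h (on this read-out higher numbers stand for weaker inhibition of growth and lower numbers for stronger inhibition of growth), compound 1 (`COc1ccccc1OCCNc1cnn(Cc2ccc(OC)c(OCC3CC3)c2)c(=O)c1Cl`) is known only as a limit (> 100000 nM). Compound 3 (`COc1ccc(Cn2ncc(NCCOc3ccccc3OC)c(Cl)c2=O)cc1OC`) is also known only as a limit (> 100000 nM). Compound 1 therefore stands at the limit of > 100000 nM in this assay, at which 2 of the 3 values shown sit, and has no true number. Going by the values given here, the one measured step from it, hydrogen in place of cyclopropyl on a saturated chain carbon bound to an oxygen on an aromatic ring, is a step that the two limits leave unreadable from compound 1 to compound 3 and offers no size to carry over. Only compound 2 (`COc1ccccc1OCCNc1ccc(=O)n(Cc2ccc(OC)c(OC3CCCC3)c2)n1`) gives a number (28000 nM), but it differs from compound 1 in more than one place.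

Compound 4 (`COc1ccccc1OCCNc1cnn(Cc2ccc(OC(F)F)c(OCC3CC3)c2)c(=O)c1Cl`) differs from compound 1 by difluoromethyl in place of methyl on an oxygen on an aromatic ring in one place: methoxy to difluoromethoxy. Among the compounds with values here, no measured step covers this change, so in this assay no step beyond the scatter is expected, and no direction is favoured. The expected step is estimated as a number no higher from compound 1 to compound 4 (the limit leaves the size open) for this reading. Compound 4 is expected near 100000 nM (estimated range 35000 nM to 200000 nM).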

Compound 4, concentration for 50% growth inhibition: 67600 nM
Compound 4: middle estimate off by 1.5-fold (0.17 log units), on the high side; measured number inside the range.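

In this assay compound 4 gives 67600 nM, so methoxy to difluoromethoxy on this oxygen yields a true number where compound 1 has none, and the change reads as an at least 1.4-fold lower number from compound 1 to compound 4 (0.17 log units; that floor lies within the scatter). Going by these compounds alone, compound 1 is known only as a limit, > 100000 nM, so this step is a floor and its full size remains unknown: the limit of > 100000 nM in this assay, at which 2 of the 4 values shown sit. The other step from compound 1, to compound 3, cannot be read, which leaves this the only change on compound 1 with any size attached, though that size does not establish a real gain.

The compounds shown leave open how the number would respond to trifluoromethyl or ethyl on the same oxygen. They also leave open whether difluoromethyl in place of methyl would give a similar step on a different core.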